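The source may hold more compounds than are shown below. What is called first, only, known or untested is meant among the compounds shown, and "the series" means these compounds.

Measured compounds:
- compound 1, `O=C(N/N=C/c1ccccc1)c1cccnc1`: > 125 ug/mL in an ADME assay on MT4 cells (Homo sapiens) for cytotoxicity, read by MTT assay, with a stated time of 4 days; on this read-out lower numbers stand for higher toxicity in this test and higher numbers for lower toxicity in this test
- compound 2, `O=C(N/N=C/c1cccc(Cl)c1)c1cccnc1`: 62 ug/mL
- compound 3, `O=C(N/N=C/c1cccc(Br)c1)c1cccnc1`: 66 ug/mL

Compound 1 stands only at a limit of this assay, (the limit of > 125 ug/mL in this assay, at which 1 of the 3 values shown sits), so no number is known for it. Compound 4, `O=C(N/N=C/c1ccc(F)cc1)c1cccnc1`, is not yet measured. Its change from compound 1 is fluoro in place of hydrogen on an aromatic carbon.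

The measured steps that bear on this are the two halogen additions on the same ring: an at least 2.0-fold lower number from compound 1 to compound 2 (0.30 log units; that floor lies within the scatter) and an at least 1.8-fold lower number from compound 1 to compound 3 (0.27 log units; that floor lies within the scatter). Both are read against the limit of compound 1, so only a floor is known, and that floor lies within the scatter. Between the two halogens, a 1.1-fold higher number from compound 2 to compound 3 (0.03 log units; within the scatter).

For compound 4 the fluoro addition is expected to behave like those steps or to fall short of them, giving a step of an at least 1.1-fold lower number from compound 1 to compound 4 (0.05 log units; that floor lies within the scatter). The estimate for compound 4 is 110 ug/mL, with a range from 55 ug/mL to 250 ug/mL, and a fair chance that this assay again reports only a limit.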

Compound 4, half-maximal cytotoxic concentration: > 125 ug/mL
Compound 4 ended at the assay's limit; the forecaster's own chance of this, stated with the estimate: 45%; middle value at least 1.1-fold (0.05 log units) from the limit.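

Compound 1 and compound 4 both stand at a limit of this assay, so the step between them cannot be read: the limit of > 125 ug/mL in this assay, at which 2 of the 4 values shown sit.

The compounds shown leave open whether fluoro in place of hydrogen on an aromatic carbon changes this read-out at all, and by how much.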